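Side-chain change on compound 3: cytotoxicity notes

The source may hold more compounds than are shown below. What is called first, only, known or untested is meant among the compounds shown, and "the series" means these compounds.

Measured so far in a functional assay on V79 cells (Cricetulus griseus) for cytotoxicity, read by colony formation; on this read-out higher numbers stand for weaker inhibition and lower numbers for stronger inhibition:
- compound 1 `CCNCC1CCN(c2c(F)cc3c(=O)c(C(=O)O)cn(C4CC4)c3c2Cl)C1`: 11 ug/mL; 11 ug/mL; < 11 ug/mL (3 entries)
- compound 2 `COc1c(F)c(N2CCC(N)C2)c(Cl)c2c1c(=O)c(C(=O)O)cn2C1CC1`: > 500 ug/mL (a limit)
- compound 3 `NC1CCN(c2c(F)c(Cl)c3c(=O)c(C(=O)O)cn(C4CC4)c3c2Cl)C1`: > 500 ug/mL (a limit)

Compound 3 has no number in this assay and stands only at a limit, (the limit of > 500 ug/mL in this assay, at which 2 of the 3 values shown sit). Going by the values given here, the one measured step is a step that the two limits leave unreadable from compound 2 to compound 3, so it gives no size to carry forward.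

Compound 4 `CCNCC1CCN(c2c(F)c(Cl)c3c(=O)c(C(=O)O)cn(C4CC4)c3c2Cl)C1` takes (ethylamino)methyl in place of amino on a saturated ring carbon. Among the compounds with values here, no measured step isolates this change.

Within the data shown here, the nearest evidence is compound 1, the only measured compound bearing (ethylamino)methyl, with the several entries of compound 1 in this assay, 11 ug/mL; 11 ug/mL; < 11 ug/mL (3 entries). One of those entries is a limit. On the strength of compound 1 at 11 ug/mL; 11 ug/mL; < 11 ug/mL (3 entries), a large move towards stronger inhibition is expected rather than a result within the scatter. That expectation rests on a single compound, so the range stays wide, and a result still at the limit cannot be ruled out.

The expected size is an at least 12-fold lower number from compound 3 to compound 4 (1.09 log units; beyond the scatter), towards stronger inhibition. For compound 4 the estimated value is 40 ug/mL, with an expected range from 10 ug/mL to 300 ug/mL.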

Compound 4, half-maximal inhibitory concentration: 270 ug/mL
Compound 4: middle estimate off by 6.8-fold (0.83 log units), on the low side, within the range that was stated.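

Replacing amino with (ethylamino)methyl on this saturated ring carbon brings the series off the limit on the core shared by compound 3 and compound 4, and this assay now gives an at least 1.8-fold lower number from compound 3 to compound 4 (0.26 log units; that floor lies within the scatter). Only a floor can be read for this step, so the change is not shown to exceed the scatter, and its true size remains unknown. Compound 1 carries the same side chain and differs from compound 4 only by a hydrogen in place of chloro on one aromatic carbon, yet its printed entries, one of which is a limit, stand at far lower numbers than those of compound 4: the several entries of compound 1 in this assay, 11 ug/mL; 11 ug/mL; < 11 ug/mL (3 entries)

The side chain alone therefore does not set the read-out, but the compounds shown leave open how the same swap of amino for (ethylamino)methyl would read on the core of compound 1, where no amino partner appears. Also open, as far as these compounds go, is which part of the new side chain matters, a question that aminomethyl or ethylamino on the same ring carbon, or a longer chain such as (propylamino)methyl, would address.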